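This account rests on a few compounds, and the source may have more. Where it says the series, first, only, none or still open, it means among the compounds named here.

In an ADME assay on MT4 cells (Homo sapiens) for cytotoxicity, read by MTT assay, with a stated time of 4 days (a lower number here means that less compound is tolerated, a higher number that more compound is tolerated), the three measured compounds give:

Compound 1 `COc1ccc(-c2cc(C)c(Nc3ccnc(Nc4ccc(C#N)cc4)n3)c(C)c2)cc1`: 2890 nM
Compound 2 `Cc1cc(-c2ccc(F)cc2)cc(C)c1Nc1ccnc(Nc2ccc(C#N)cc2)n1`: 4170 nM
Compound 3 `Cc1cc(-c2cccc(F)c2)cc(C)c1Nc1ccnc(Nc2ccc(C#N)cc2)n1`: 4120 nM

Compound 3 sits with the other two: the step of a 1.0-fold lower number from compound 2 to compound 3 (0.01 log units; within the scatter) and the step of a 1.4-fold higher number from compound 1 to compound 3 (0.15 log units; within the scatter) are both within the scatter, so no ranking among them can be read from these numbers. Compound 4 `Cc1cc(C)cc(-c2cc(C)c(Nc3ccnc(Nc4ccc(C#N)cc4)n3)c(C)c2)c1` differs from compound 3 only in the group on the outer aromatic ring: 3,5-dimethylphenyl in place of 3-fluorophenyl on an aromatic carbon. The measured steps that bear on this all change that same outer ring group: a 1.4-fold higher number from compound 1 to compound 2 (0.16 log units; within the scatter), a 1.4-fold higher number from compound 1 to compound 3 (0.15 log units; within the scatter) and a 1.0-fold lower number from compound 2 to compound 3 (0.01 log units; within the scatter), each within the scatter. Swapping this group has so far left the number essentially unchanged, so no step beyond the scatter is expected here either: the expected step is a 1.0-fold lower number from compound 3 to compound 4 (0.01 log units; within the scatter). Compound 4 is therefore estimated at 4000 nM in this assay, with a range from 1500 nM to 10000 nM.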

Compound 4, half-maximal cytotoxic concentration: 4140 nM
Compound 4: middle estimate off by 1.0-fold (0.01 log units), on the low side, and the stated range covers the measured number.
By their numbers in this assay, from the lowest: compounds 1, 3, 4 and 2 (each within the scatter of the next).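

With methyl groups on the outer ring in place of a fluoro or methoxy group, the steps in this assay all stay within the scatter: a 1.0-fold higher number from compound 3 to compound 4 (0.00 log units; within the scatter), a 1.0-fold lower number from compound 2 to compound 4 (0.00 log units; within the scatter) and a 1.4-fold higher number from compound 1 to compound 4 (0.16 log units; within the scatter). Across these four compounds, then, no outer ring group at this position stands apart from the others. Nothing measured here offers an explanation for this.

From the compounds shown here alone, whether an outer ring bearing an amine or a carboxylic acid would also stay within the scatter remains open.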